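Swapping the halogenated ring in compound 2 for ethylphenyl

This account rests on a few compounds, and the source may have more. Where it says the series, first, only, none or still open, it means among the compounds named here.

Compound 1, `Oc1cc(F)ccc1C(c1ccc2ccoc2c1O)N1CCCCC1`: 1070 nM in an assay for inhibition of protein disulfide-isomerase (Homo sapiens), with a stated time of 1 h; a higher number here means a weaker inhibitor, a lower number a stronger inhibitor
Compound 2, `Cc1ccnc(NC(c2ccc3cccnc3c2O)c2c(F)cccc2Cl)c1`: > 40000 nM in this assay, reported only as a limit

Compound 2 stands at the edge of what this assay can report: its result is a limit, not a number, and it sits at the limit of > 40000 nM in this assay, at which 1 of the 2 values shown sits. Among the measured compounds shown here, compound 1 does give a number, 1070 nM, but its core differs from that of compound 2, so no step between the two is available and the values show only that compound 1 is the one with a measured figure.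

Compound 3, `CCc1ccc(C(Nc2cc(C)ccn2)c2ccc3cccnc3c2O)cc1`, differs from compound 2 by 4-ethylphenyl in place of 2-chloro-6-fluorophenyl on a saturated chain carbon bound to an aromatic carbon and a nitrogen on an aromatic ring. For the measured compounds named here, no measured step covers this change, so any expectation rests on compound 2 alone. The step of a number no higher from compound 2 to compound 3 (the limit leaves the size open) is estimated to be small, likely within the scatter, with a real chance that this assay again returns only a limit. Compound 3 is expected near 40000 nM, within a range from 8000 nM to 200000 nM.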

Compound 3, half-maximal inhibitory concentration: 5390 nM
Estimate against measurement, compound 3: 7.4-fold (0.87 log units) above; measured number outside the range, below it.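

Replacing 2-chloro-6-fluorophenyl with 4-ethylphenyl on a saturated chain carbon bound to an aromatic carbon and a nitrogen on an aromatic ring gives, in this assay, an at least 7.4-fold lower number from compound 2 to compound 3 (0.87 log units; beyond the scatter). This shows that the group at this place affects the read-out and that the core shared by compound 2 and compound 3 can give a measured figure, which compound 2 alone did not show. The full size of the step stays unknown, since the result for compound 2 is only a limit: the limit of > 40000 nM in this assay, at which 1 of the 3 values shown sits.

The compounds shown do not separate the loss of the chlorine and fluorine from the gain of the ethyl group. They also leave open how a phenyl ring carrying a longer chain, a methoxy group or an amine would read at this place.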